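The source may report more compounds than this note shows. Statements on the series, on what has been measured and on what is new or still open speak of the compounds shown alone.

Measured so far:
compound 1 `Nc1cc(N)c2nc(-c3ccccc3)c(NCc3ccc(F)cc3)nc2c1`, 15100 nM
compound 2 `COc1ccc(CNc2nc3cc(N)cc(N)c3nc2-c2ccccc2)cc1`, 16200 nM

Both numbers come from a functional assay on CAKI-1 cells (Homo sapiens) for inhibition, read by sulforhodamine B assay, with a stated time of 48 h; on this read-out lower numbers stand for stronger inhibition of growth and higher numbers for weaker inhibition of growth. Compound 1 has the lowest of the two numbers, and compound 2 is its nearest neighbour; the change from compound 1 to compound 2, methoxy in place of fluoro on an aromatic carbon, gives a 1.1-fold higher number from compound 1 to compound 2 (0.03 log units; within the scatter), so the two compounds cannot be told apart.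

Compound 3 `Nc1cc(N)c2nc(-c3ccccc3)c(Oc3ccc(F)cc3)nc2c1` is not yet measured. It differs from compound 1 in one place: 4-fluorophenoxy in place of (4-fluorobenzyl)amino on an aromatic carbon. Going by the values given here, the only measured step, from compound 1 to compound 2, touches the substituent on the pendant ring and not the link between that ring and the shared core, so it does not bear on the change to compound 3. Among the compounds with values here, with no step that speaks to an oxygen link in place of an amino link, there is no ground in these numbers for a step in either direction beyond the scatter. On that basis compound 3 is expected to give about 20000 nM in this assay, with a range from 7000 nM to 60000 nM, which means an estimated step of a 1.3-fold higher number from compound 1 to compound 3 (0.12 log units; within the scatter).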

Compound 3, concentration for 50% growth inhibition: 11200 nM
Beside the measured number, compound 3's estimate is 1.8-fold (0.25 log units) above it; the measured number falls inside the stated range.
By their numbers in this assay, from the lowest: compounds 3, 1 and 2 (each within the scatter of the next).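

In this assay, replacing (4-fluorobenzyl)amino with 4-fluorophenoxy on the aromatic carbon next to the ring nitrogen gives a 1.3-fold lower number from compound 1 to compound 3 (0.13 log units; within the scatter), so this change cannot be told apart from no change in the number. It is the first step shown that alters the link to the pendant ring rather than a substituent on that ring, and it shows that compound 3, whose entering group has 0 hydrogen-bond donors and one heavy atom fewer than the group that leaves, stays level with compound 1 in this read-out. No measurement of any underlying property accompanies this result, so the step can be reported only as a difference in growth inhibition.

As far as these compounds go, whether a thioether sulfur as the link, a piperazine in its place, or a carboxylic acid on the pendant ring would move the number beyond the scatter remains open. From the compounds shown here alone, the phenyl group and the amino groups on the shared core are the same in compounds 1, 2 and 3, so what changes at those places would do also stays open.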